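Aryl sulfonyl quinoline series: liver microsome clearance notes

The source may report more compounds than this note shows. Statements on the series, on what has been measured and on what is new or still open speak of the compounds shown alone.

Measured compounds:
compound 1 `O=S(=O)(c1ccc(F)c(F)c1)c1cnc2cc(F)ccc2c1-c1cccc(Cl)c1` gives 0.38 mL/min
compound 2 `O=S(=O)(c1ccc(F)c(Cl)c1)c1cnc2cc(F)ccc2c1-c1ccc(F)cc1` gives 0.69 mL/min
compound 3 `O=S(=O)(c1ccc(F)c(Cl)c1)c1cnc2cc(F)ccc2c1-c1cccc(Cl)c1` gives 0.66 mL/min

All three were run in an ADME assay on microsomes from liver (Homo sapiens) for metabolic stability, tested at 2.5 uM; a higher number here means faster removal of the compound, a lower number slower removal. Compound 3 stands second highest of the three numbers, but its nearest neighbour is compound 2 at a gap inside the scatter, and even compound 1, the furthest, sits within the scatter of it: a 1.7-fold higher number from compound 1 to compound 3 (0.24 log units; within the scatter). The aryl swap in the same position is likewise flat: a 1.0-fold lower number from compound 2 to compound 3 (0.02 log units; within the scatter).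

The next compound is compound 4 `O=S(=O)(c1ccc(F)c(Cl)c1)c1cnc2cc(F)ccc2c1-c1ccccc1F`. Relative to compound 3 the change is 2-fluorophenyl in place of 3-chlorophenyl on an aromatic carbon. Within the data shown here, the one measured step that bears on this position, from compound 2 to compound 3, was within the scatter, and the sulfonyl-side step from compound 1 to compound 3 was also within the scatter. Among the measured compounds shown here, no measured step here moves this assay beyond its noise, so no directional shift is expected for compound 4; the expected step is a 1.1-fold lower number from compound 3 to compound 4 (0.03 log units; within the scatter). Compound 4 is therefore estimated at 0.62 mL/min, with a range from 0.32 mL/min to 1.2 mL/min.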

Compound 4, intrinsic clearance in a liver preparation (reported as CLH), per the amount of preparation that the assay uses: 1.07 mL/min
The estimate for compound 4 lay 1.7-fold (0.24 log units) below the measured number, and the stated range covers the measured number.
By their numbers in this assay, from the lowest: compounds 1, 3, 2 and 4 (each within the scatter of the next, the first and the last beyond it).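

In this assay, placing 2-fluorophenyl at this position gives a 1.6-fold higher number from compound 3 to compound 4 (0.21 log units; within the scatter) and a 1.6-fold higher number from compound 2 to compound 4 (0.19 log units; within the scatter) on the same sulfonyl side. Both steps lie within the scatter, so with a third aryl group at this position, 3-chlorophenyl, 4-fluorophenyl and 2-fluorophenyl still cannot be told apart, and moving the halogen around this phenyl ring has shown no step beyond the scatter in compounds 2, 3 and 4. No measurement at hand speaks to the reason for the size of these steps.

On these data alone, it remains open whether an amine or a carboxylic acid on this phenyl ring would carry the number beyond the scatter. As far as these compounds go, it is also open whether 2-fluorophenyl behaves the same way alongside the sulfonyl-side aryl group of compound 1.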